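The source may report more compounds than this note shows. Statements on the series, on what has been measured and on what is new or still open speak of the compounds shown alone.

The measured compounds and their values:

compound 1 `O=C(Nc1cccc(-n2cc(-c3ccncc3)c(-c3ccc(Cl)c(O)c3)n2)c1)Nc1ccc(Cl)c(Cl)c1`: 1460 nM
compound 2 `COc1cc(-c2nn(-c3cccc(NC(=O)c4ccc(Cl)c(C(F)(F)F)c4)c3)cc2-c2ccncc2)ccc1Cl`: 3080 nM
compound 3 `COc1cc(-c2nn(-c3cccc(NC(=O)Nc4cccc(C(F)(F)F)c4)c3)cc2-c2ccncc2)ccc1Cl`: 1120 nM

In a functional assay on SK-MEL-28 cells (Homo sapiens) for inhibition, read by sulforhodamine B assay, with a stated time of 48 h (on this read-out higher numbers stand for weaker inhibition of growth and lower numbers for stronger inhibition of growth), compound 1 stands second highest of the three numbers; compound 3 lies within the scatter of it, while compound 2 lies beyond the scatter on the higher side. Compound 4 `O=C(Nc1cccc(-n2cc(-c3ccncc3)c(-c3ccc(Cl)c(O)c3)n2)c1)Nc1ccc(Cl)c(C(F)(F)F)c1` differs from compound 1 by trifluoromethyl in place of chloro on an aromatic carbon. Among the compounds with values here, the only measured step, a 2.8-fold lower number from compound 2 to compound 3 (0.44 log units; beyond the scatter), changes a different part of the molecule and so does not speak to this swap. Within the data shown here, with no measured step touching it, the change is expected to give no step beyond the scatter in this assay. Compound 4 is therefore estimated at 1500 nM, between 600 nM and 3800 nM, which means an expected step of a 1.0-fold higher number from compound 1 to compound 4 (0.01 log units; within the scatter).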

Compound 4, concentration for 50% growth inhibition: 978 nM
Estimate against measurement, compound 4: 1.5-fold (0.19 log units) above; measured number inside the range.
By their numbers in this assay, from the lowest: compounds 4, 3 and 1 (each within the scatter of the next); then compound 2.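

Trifluoromethyl in place of chloro, ortho to a chloro group on the aromatic ring, gives a 1.5-fold lower number from compound 1 to compound 4 (0.17 log units; within the scatter) in this assay. This position therefore takes a group of four heavy atoms in place of a single atom, and the two compounds stay within the scatter of each other. No measurement available here accounts for this result.

The compounds shown leave open how a nitrile or an amine at this position would read in this assay. They also leave open whether this swap would read the same on a core carrying methoxy, as in compound 3 .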